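A Cyano Group Replaces Chloro on a Weakly Cytotoxic Core

The source may hold more compounds than are shown below. What is called first, only, known or untested is meant among the compounds shown, and "the series" means these compounds.

Compound 2 `OC[C@@H]1C[C@H](CO)[C@@H]2C(c3ccc(Cl)cc3)=NO[C@H]12` was tested in a functional assay on A549 cells (Homo sapiens) for cytotoxicity, read by MTT assay, with a stated time of 48 h; a higher number here means a weaker inhibitor, a lower number a stronger inhibitor. In this assay compound 2 gives > 50 ug/mL, which is a limit of the assay and not a number. Compound 1 `OC[C@@H]1C[C@H](CO)[C@@H]2C(c3ccccc3Cl)=NO[C@H]12` likewise reaches the limit of > 50 ug/mL in this assay. Compound 3 `COc1ccc(C2=NO[C@@H]3[C@H](CO)C[C@H](CO)[C@H]23)cc1`, by contrast, gives a measured value of 36.6 ug/mL in this assay. Only one step among these compounds is known: an at least 1.3-fold lower number from compound 2 to compound 3 (0.13 log units; that floor lies within the scatter). Its floor lies within the scatter, and the limit of > 50 ug/mL in this assay, at which 2 of the 3 values shown sit, leaves the true size of that change open.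

Compound 4 `N#Cc1ccc(C2=NO[C@@H]3[C@H](CO)C[C@H](CO)[C@H]23)cc1` differs from compound 2 in one place: cyano in place of chloro on an aromatic carbon. Going by the values given here, no measured step touches a cyano group, so the step from compound 2 to compound 3 is the only guide, and it points, if anywhere, toward a smaller number. Since methoxy and cyano are different groups, the expectation stays close to the limit.

Compound 4 is expected to give about 45 ug/mL in this assay, somewhere within 20 ug/mL to 100 ug/mL. The estimated step of an at least 1.1-fold lower number from compound 2 to compound 4 (0.04 log units; that floor lies within the scatter) is expected to stay within the scatter.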

Compound 4, half-maximal inhibitory concentration: > 50 ug/mL
Compound 4 gave a limit, no number (the forecaster's own chance of this, stated with the estimate: 55%); middle value at least 1.1-fold (0.04 log units) from the limit.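

In this assay compound 4 yields only a limit of the assay and not a number, so cyano in place of chloro on this aromatic carbon, para to a large group, produces no readable step, and the step between compound 2 and compound 4 cannot be read. Set against methoxy at the same place, the cyano group gives an at least 1.3-fold higher number from compound 3 to compound 4 (0.13 log units; that floor lies within the scatter), so these data do not establish a real difference between the two groups. With a second group tested at this position, the limit now accounts for most of the readings: the limit of > 50 ug/mL in this assay, at which 3 of the 4 values shown sit.

On these data alone, the true values of compound 2 and compound 4 stay open, as does whether the measured value of compound 3 reflects anything particular to methoxy. Also open, as far as these compounds go, is whether an amine or a carboxylic acid on this aromatic carbon would give a number in this assay.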